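The compounds below may be only part of what the source reports. "The series", "measured", "known", "first", "only" and "open" are said of these compounds alone.

Measured compounds:

- Compound 1, `O=C(CN(c1ncnc2c1ncn2C1CCCCO1)C1CC1)NCC(=O)OCc1ccccc1`: 55.7%
- Compound 2, `C[C@@H](O)[C@H](NC(=O)CN(c1nc(Cl)nc2[nH]cnc12)C1CC1)C(=O)O`: 18.6%
- Compound 3, `NCCCC[C@H](NC(=O)CN(c1nc(Cl)nc2[nH]cnc12)C1CC1)C(=O)O`: 31.2%

In a functional assay on the whole organism (Tail, strain ICR) with Mus musculus as the target, in the tail flick test, with a stated time of 30 min, at a dose of 25 umol/kg by the oral route (a lower number here means a weaker effect, a higher number a stronger effect of the compound at the dose given), compound 1 gives the highest of the three numbers, standing beyond the scatter above both compound 3 and compound 2. Among the measured compounds, compound 2 and compound 3 share a core that differs from the core of compound 1, and they differ from each other only in the group on the saturated chain carbon bound to the amide-type nitrogen and the carbonyl carbon; that change gave a number 12.6 percentage points higher from compound 2 to compound 3 (beyond the scatter).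

Compound 4, `CC(C)C[C@H](NC(=O)CN(c1ncnc2c1ncn2C1CCCCO1)C1CC1)C(=O)OCc1ccccc1`, has not yet been measured. It differs from compound 1 in one place: isobutyl in place of hydrogen on a saturated chain carbon bound to an amide-type nitrogen and a carbonyl carbon. The step from compound 2 to compound 3 touches the same place in the chain, but on a different core and with a different pair of groups, so it does not tell how adding isobutyl where hydrogen stood will act. Within the data shown here, no measured step bears directly on this change. With compound 1 at 55.7% as the only anchor, the step in this assay is expected to stay small, in either direction, and compound 4 is estimated at 50% (range 30% to 70%), which would mean an expected step of a number 5.7 percentage points lower from compound 1 to compound 4 (within the scatter).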

Compound 4, a percentage reported as activity, at one dose (the size of the read-out at that dose, not a potency): 26.2%
Compound 4: the middle estimate sits 23.8 percentage points above what was measured, and the stated range ends above it.
By their numbers in this assay, from the lowest: compounds 2, 4 and 3 (each within the scatter of the next, the first and the last beyond it); then compound 1.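

In this assay, isobutyl in place of hydrogen on the saturated chain carbon bound to an amide-type nitrogen and a carbonyl carbon gave a number 29.5 percentage points lower from compound 1 to compound 4 (beyond the scatter) on the core of compound 1, so this position is not indifferent to what it carries. The earlier step at this place compared two groups on a different core, whereas this one compares a bare hydrogen with a carbon chain on the same core, and here the compound with hydrogen keeps the higher number. With a single step on this core, this is one observation about one group and not a trend with group size, and nothing in the data shown gives a reason for the drop.

From the compounds shown here alone, it remains open whether a smaller group such as methyl at this place, on the core of compound 1, would stay closer to compound 1 or fall as far as compound 4. Going by these compounds, it is equally open whether an oxygen-bearing group such as hydroxymethyl, or a straight butyl chain, would read differently from isobutyl on that core.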